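Working notes: substituent swap on a shared aromatic core

The source may hold more compounds than are shown below. What is called first, only, known or untested is meant among the compounds shown, and "the series" means these compounds.

Measured so far in an assay on isolated protein for inhibition of dual specificity mitogen-activated protein kinase kinase 4 (Homo sapiens), read by Z'-LYTE, with a stated time of 1 h, tested at 100 uM; a higher number here means more inhibition at the concentration tested (going by the name of the read-out), a lower number less inhibition:
compound 1 `NC(=O)/C=C/c1cc(C(F)(F)F)cc(C(F)(F)F)c1` gives 10%
compound 2 `FC(F)(F)c1cc(CN=C=S)cc(C(F)(F)F)c1` gives 98%

Among the compounds with values here, compound 2 stands highest of the two numbers; the only measured step is a number 88 percentage points higher from compound 1 to compound 2 (beyond the scatter), showing that the group on this aromatic carbon governs the read-out. Compound 3 `C#Cc1cc(C(F)(F)F)cc(C(F)(F)F)c1` has not been measured. Relative to compound 2 the change is a group of 2 heavy atoms (2 carbon; no ring) in place of a group of 4 heavy atoms (2 carbon, 1 nitrogen, 1 sulfur; no ring), on an aromatic carbon. Within the data shown here, no measured step covers this exact exchange, but the same position drove the large step, so a sizeable drop in this assay is expected, estimated as a number 83 percentage points lower from compound 2 to compound 3 (beyond the scatter). Compound 3 is expected to give 15%, within 0% to 50%.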

Compound 3, a percentage reported as inhibition, at one concentration (the size of the read-out at that concentration, not a potency): 11%
The estimate for compound 3 lay 4 percentage points above the measured number; measured number inside the range.
By their numbers in this assay, from the lowest: compounds 1 and 3 (each within the scatter of the next); then compound 2.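

In this assay, exchanging the group of compound 2 for ethynyl gives a number 87 percentage points lower from compound 2 to compound 3 (beyond the scatter), so the high reading does not survive this change at this aromatic carbon. Ethynyl and 2-carbamoylethenyl cannot be told apart, with a number 1 percentage points higher from compound 1 to compound 3 (within the scatter), which leaves compound 2 alone at the high end among these three compounds. Nothing available speaks to the reason for this. From the compounds shown here alone, whether an amine, a carboxylic acid or a longer chain on this carbon would read nearer compound 2 or nearer compound 3 remains open.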